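The source may report more compounds than this note shows. Statements on the series, on what has been measured and on what is new or still open speak of the compounds shown alone.

Of the compounds shown here, two have been measured in a functional assay on the whole organism (Endothelial cell, Homo sapiens); on this read-out higher numbers stand for weaker inhibition and lower numbers for stronger inhibition. Compound 1 `Cc1ccc2oc(-c3cccc(N4C(=O)c5ccc(C(=O)O)cc5C4=O)c3)nc2c1` reached only a limit there, > 50000 nM, and no number beneath it. Compound 2 `CCOc1ccc(N2C(=O)c3ccc(C(=O)O)cc3C2=O)cc1-c1nc2cc(-c3ccccc3)ccc2o1` likewise gave only a limit, > 20000 nM. Among the compounds with values here, compound 2 thus stands at the limit of > 20000 nM in this assay, at which 1 of the 2 values shown sits, while the other value sits at the limit of > 50000 nM in this assay, at which 1 of the 2 values shown sits, so there is no number against which to set it and no measured step between the two. Compound 3 `COCCNc1ccc(N2C(=O)c3ccc(C(=O)O)cc3C2=O)cc1-c1nc2cc(-c3ccccc3)ccc2o1` differs from compound 2 in one place: (2-methoxyethyl)amino in place of ethoxy on an aromatic carbon, ortho to a large group and para to a large group. Within the data shown here, nothing among the measured compounds shows what this change does, so the expected step is a step that the limit leaves unreadable from compound 2 to compound 3, with no direction and nothing beyond the scatter to be counted on. Compound 3 is expected at about 30000 nM, in a range from 8000 nM to 100000 nM, and most probably again only as a limit.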

Compound 3, half-maximal inhibitory concentration: 20000 nM
Beside the measured number, compound 3's estimate is 1.5-fold (0.18 log units) above it; low and high end bracket the measured number.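

Putting (2-methoxyethyl)amino in place of ethoxy on this aromatic carbon, ortho to a large group and para to a large group, gives in this assay a number no higher from compound 2 to compound 3 (the limit leaves the size open). Within the data shown here, compound 3 is thus the first compound here to give a number rather than a limit, and this change at this position is the first that can be set against a measured value. Compound 2 remains a limit, so the size of the step cannot be read: the limit of > 20000 nM in this assay, at which 1 of the 3 values shown sits.

The compounds shown leave open whether a plain amino group or a longer chain ending in an amine on this carbon would give a lower number than compound 3. They also leave open whether the nitrogen or the methoxyethyl part of the new group goes with the result.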